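A few compounds are considered here, and "the series" means these few. Any claim that something is new, unique, unknown or untested is made for them only; others in the source may bear on it.

Working notes on the series. In a functional assay on PC-3 cells (Homo sapiens) for cytotoxicity, read by colorimetric assay and MTT assay (a lower number here means a stronger inhibitor, a higher number a weaker inhibitor), compound 1 `COc1cc(OC)c2cc(-c3ccccc3)c(O)nc2c1` gives 10000 nM as its reading, and compound 2 `COc1ccc(-c2cc3c(OC)cc(OC)cc3n(CC#N)c2=O)cc1` gives 10000 nM as well, so compound 2 stands level with compound 1 at the digits shown and within the scatter. Within the data shown here, no measured pair differs in one place only, so no measured step is available as a guide. Compound 3 `CCN(CC)C(=O)CCn1c(=O)c(-c2ccc(OC)cc2)cc2c(OC)cc(OC)cc21` still awaits its measurement. It departs from compound 2 by the change (diethylcarbamoyl)methyl in place of cyano on a saturated chain carbon bound to an aromatic nitrogen in which (diethylcarbamoyl)methyl stands in place of cyano on a saturated chain carbon bound to an aromatic nitrogen. Cut one bond further out, the same difference reads cyanomethyl to 2-(diethylcarbamoyl)ethyl. The expectation in this assay is no step beyond the scatter in either direction, and it rests only on compound 2 with its 10000 nM as the starting point. The estimated step of no change at the digits printed from compound 2 to compound 3 (within the scatter) is expected to stay that small. For compound 3 the expected value is 10000 nM within an estimated range of 3000 nM to 20000 nM for now.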

Compound 3, half-maximal inhibitory concentration: 10000 nM
Estimate against measurement, compound 3: no gap at the digits printed; measured number inside the range.
By their numbers in this assay, from the lowest: compounds 1, 2 and 3 (each within the scatter of the next).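

Among these compounds, the only step measured at this place, in this assay, is no change at the digits printed from compound 2 to compound 3 (within the scatter) when (diethylcarbamoyl)methyl stands in place of cyano on a saturated chain carbon bound to an aromatic nitrogen. The change is a large one in counted terms: 8 heavy atoms enter where 2 leave, a carbonyl-type double bond replaces the triple bond outside aromatic rings, and the hydrogen-bond donor and acceptor counts match, yet this larger group gives a reading level with that of the nitrile within the scatter. Nothing measured here gives a reason for this outcome, and a level reading for this one pair does not show that the place is insensitive to every group.

The compounds shown leave open whether a group of another kind on the same chain, such as a tertiary amine or a carboxylic acid, would give a reading apart from that of compound 3 at 10000 nM in this assay. They also leave open whether a longer chain, or a change elsewhere on the shared core, such as replacing the methoxy groups, would separate any compound from this level.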